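A few compounds are considered here, and "the series" means these few. Any claim that something is new, unique, unknown or untested is made for them only; others in the source may bear on it.

In a functional assay on MCF7 cells (Homo sapiens) for antiproliferative activity, read by MTT assay, with a stated time of 48 h (a lower number here means a stronger inhibitor, a higher number a weaker inhibitor), compound 1 `COc1cccc(-c2nc3cccc(-c4cc(OC)c(OC)c(OC)c4)c3o2)c1` gives only a limit, > 25000 nM, so its true strength is not known. Two close relatives behave the same way. Compound 2 `COc1cc(-c2cccc3nc(-c4cccc(Cl)c4)oc23)cc(OC)c1OC`, with chloro in place of methoxy on an aromatic carbon, also reaches only the limit > 25000 nM. Compound 3 `COc1cc(-c2cccc3nc(-c4ccc(N)cc4)oc23)cc(OC)c1OC`, with 4-aminophenyl in place of 3-methoxyphenyl on an aromatic carbon, likewise gives the limit > 25000 nM. Because every value shown sits at the limit of > 25000 nM in this assay, at which 3 of the 3 values shown sit, none of the steps among these three can be read: a step that the two limits leave unreadable from compound 1 to compound 2, a step that the two limits leave unreadable from compound 1 to compound 3 and a step that the two limits leave unreadable from compound 2 to compound 3 all remain of unknown size.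

Compound 4 `COc1cc(-c2cccc3nc(-c4cccc(N)c4)oc23)cc(OC)c1OC` differs from compound 1 by amino in place of methoxy on an aromatic carbon. The measured steps bear on this change only in that each of them is unreadable; they neither support nor rule out a shift, and no direction can be drawn from them. The step that the limit leaves unreadable from compound 1 to compound 4 is therefore expected to be too small to lift compound 4 above the limit. Compound 4 is estimated at 35000 nM in this assay, with a range from 8000 nM to 150000 nM, and most likely only a limit will be reported for it.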

Compound 4, half-maximal inhibitory concentration: > 25000 nM
Compound 4: no number, only a limit; the forecaster's own chance of this, stated with the estimate: 85%; the middle value lies beyond the limit too.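

Compound 4 also stops at a limit rather than a number, so its steps to compound 1, compound 2 and compound 3 cannot be read, because all four compounds end at the same limit: the limit of > 25000 nM in this assay, at which 4 of the 4 values shown sit.

The compounds shown leave open how strong any of the four truly is in this assay and whether any of these changes shifts that strength.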